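From methoxy to hydroxy in a well-tolerated compound

This account rests on a few compounds, and the source may have more. Where it says the series, first, only, none or still open, it means among the compounds named here.

Measured so far in an ADME assay on FHC cells (Homo sapiens) for cytotoxicity, read by resazurin assay, with a stated time of 48 h; a higher number here means that more compound is tolerated, a lower number that less compound is tolerated
- compound 1 `O=S(=O)(Nc1ccc(-c2nc3cc(NS(=O)(=O)c4ccccc4)ccc3o2)cc1)c1ccccc1` gives 30000 nM
- compound 2 `O=C(Nc1ccc(Sc2nc3ccccc3s2)c(Cl)c1)c1cccc(Br)c1O` gives > 100000 nM (a limit)
- compound 3 `COc1c(Br)cccc1C(=O)Nc1ccc(Sc2nc3ccccc3s2)cc1` gives > 100000 nM (a limit)

Compound 3 stands at the limit of > 100000 nM in this assay, at which 2 of the 3 values shown sit, and so has no exact number. Compound 4 `O=C(Nc1ccc(Sc2nc3ccccc3s2)cc1)c1cccc(Br)c1O` differs from it in one place, with hydrogen in place of methyl on an oxygen on an aromatic ring, so methoxy becomes hydroxy (hydrogen in place of methyl on an oxygen on an aromatic ring). Within the data shown here, no measured pair shows what this change does. With compound 3 at > 100000 nM as a limit, compound 4 is expected to stay well tolerated in this assay, with no step beyond the scatter. The estimated change is a number no higher from compound 3 to compound 4 (the limit leaves the size open) and the result may again be only a limit. For compound 4 the estimated value is 100000 nM with a range from 30000 nM to 200000 nM expected.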

Compound 4, half-maximal cytotoxic concentration: 59000 nM
Estimate against measurement, compound 4: 1.7-fold (0.23 log units) above, within the range that was stated.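

In this assay, among these compounds, compound 4 gives the first exact number among the compounds sharing its core. Methoxy to hydroxy on this oxygen on an aromatic ring gives an at least 1.6-fold lower number from compound 3 to compound 4 (0.22 log units; that floor lies within the scatter) here, and hydrogen in place of chloro on an aromatic carbon gives an at least 1.6-fold lower number from compound 2 to compound 4 (0.22 log units; that floor lies within the scatter) in the same assay. Neither step can be sized, because compound 2 and compound 3 have no exact number: the limit of > 100000 nM in this assay, at which 2 of the 4 values shown sit.

As far as these compounds go, it remains open how a longer chain such as ethyl on that oxygen, or an amine in place of the hydroxy, would read in this assay.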